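This account rests on a few compounds, and the source may have more. Where it says the series, first, only, none or still open, it means among the compounds named here.

Measured in a functional assay on SK-BR-3 cells (Homo sapiens) for antiproliferative activity, with a stated time of 72 h; on this read-out higher numbers stand for weaker inhibition of growth and lower numbers for stronger inhibition of growth:
- compound 1 `COc1ccc(CN(C)C(=O)c2cc(Cl)c(O)cc2O)cc1OC`: 7700 nM
- compound 2 `Cc1cccc(CN(C)C(=O)c2cc(Cl)c(O)cc2O)c1`: 11300 nM
- compound 3 `COc1cc(CN(C)C(=O)c2cc(Cl)c(O)cc2O)cc(OC)c1OC`: 30100 nM

The number for compound 2 lies within the scatter of that for compound 1 and is lower than that for compound 3. Compound 4 `Cc1ccc(CN(C)C(=O)c2cc(Cl)c(O)cc2O)cc1` differs from compound 2 by one change: 4-methylphenyl in place of 3-methylphenyl on a saturated chain carbon bound to an amide-type nitrogen, with 4-methylphenyl in place of 3-methylphenyl. Among the measured compounds shown here, no measured pair shows this kind of change. The nearest evidence is a 3.9-fold higher number from compound 1 to compound 3 (0.59 log units; beyond the scatter), where a methoxy replaces a hydrogen on an aromatic carbon, so a modest step came from adding a group. Compound 4 adds nothing, as it has the same atoms joined differently. The estimated step is a 1.1-fold lower number from compound 2 to compound 4 (0.05 log units; within the scatter), and it is not expected to go beyond the scatter. In this assay, compound 4 is expected at 10000 nM, within an estimated range of 4500 nM to 24000 nM.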

Compound 4, concentration for 50% growth inhibition: 7200 nM
For compound 4 the middle estimate is 1.4-fold (0.14 log units) above the measured one, and the stated range covers the measured number.
By their numbers in this assay, from the lowest: compounds 4, 1 and 2 (each within the scatter of the next); then compound 3.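

Moving the methyl group, with 4-methylphenyl in place of 3-methylphenyl, gives a 1.6-fold lower number from compound 2 to compound 4 (0.20 log units; within the scatter), so this pair cannot be told apart in growth inhibition. Unlike the earlier methoxy step, this change adds no atoms, and here it shifts the number by no more than repeat measurements normally would. No supporting measurement bears on why these two compounds match. Going by these compounds, it remains open whether an ethyl group, a longer chain, would fit as well as methyl. On these data alone, an amine or a carboxylic acid in its place also remains untested by these compounds.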